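From 4-methylphenyl to thiophen-2-yl on the sulfonyl sulfur

This account rests on a few compounds, and the source may have more. Where it says the series, first, only, none or still open, it means among the compounds named here.

In a functional assay on MCF7 cells (Homo sapiens) for antiproliferative activity, read by sulforhodamine B assay, with a stated time of 72 h (on this read-out higher numbers stand for weaker inhibition and lower numbers for stronger inhibition), compound 3 (`Cc1ccc(S(=O)(=O)Nc2cc(SCCC(=O)N[C@@H](CC(C)C)B(O)O)c(O)c3ccccc23)cc1`) gives 6940 nM. That lies within the scatter of compound 1 (`Cc1ccc(S(=O)(=O)Nc2cc(SCC(=O)N[C@@H](CC(C)C)B(O)O)c(O)c3ccccc23)cc1`) at 12800 nM and of compound 2 (`CC(C)C[C@H](NC(=O)CSc1cc(NS(=O)(=O)c2ccc(Cl)cc2)c2ccccc2c1O)B(O)O`) at 10400 nM. Compound 4 (`CC(C)C[C@H](NC(=O)CCSc1cc(NS(=O)(=O)c2cccs2)c2ccccc2c1O)B(O)O`) carries thiophen-2-yl in place of 4-methylphenyl on a sulfonyl sulfur. The closest measured change also alters the group on the sulfonyl sulfur: chloro in place of methyl gave a 1.2-fold lower number from compound 1 to compound 2 (0.09 log units; within the scatter). Lengthening the chain on the other side gave a 1.8-fold lower number from compound 1 to compound 3 (0.27 log units; within the scatter). Among the measured compounds shown here, neither step left the scatter, but no measured compound holds a thiophen-2-yl group. The expected result is therefore only a small move, a 1.1-fold higher number from compound 3 to compound 4 (0.03 log units; within the scatter), within the scatter. For compound 4 the estimate is 7500 nM, with an expected range from 3000 nM to 18000 nM.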

Compound 4, half-maximal inhibitory concentration: 6470 nM
For compound 4 the middle estimate is 1.2-fold (0.06 log units) above the measured one; low and high end bracket the measured number.
By their numbers in this assay, from the lowest: compounds 4, 3, 2 and 1 (each within the scatter of the next).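

In this assay, thiophen-2-yl in place of 4-methylphenyl on the sulfonyl sulfur gives a 1.1-fold lower number from compound 3 to compound 4 (0.03 log units; within the scatter), which shows that the number holds when a five-membered aromatic ring with a sulfur replaces the six-membered carbon ring. The earlier compounds shown here changed only the methyl to chloro on that six-membered ring. No separate measurement bears on this result. Still open, as far as these compounds go, is whether an open butyl chain, or a ring carrying an amine or a carboxylic acid, would leave the number within the scatter at this position.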